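Replacing the aryl group on compound 2

The compounds below may be only part of what the source reports. "The series", "measured", "known", "first", "only" and "open" are said of these compounds alone.

In a physicochemical assay for lipophilicity (a lower number here means a more polar compound, a higher number a more lipophilic compound), compound 1 (`N#Cc1ccc(Cn2cncc2CN2CCN(c3cccc(Cl)c3)CC2=O)cc1`) gives 2.51 and compound 3 (`N#Cc1ccc(Cn2cncc2C(=O)N2CCN(c3cccc(Cl)c3)CC2)cc1`) gives 2.79 with the two lying within the scatter of each other. Compound 2 (`N#Cc1ccc(Cn2cncc2CN2CCN(c3cccc(Cl)c3)C(=O)C2=O)cc1`) stands lowest of the three at 1.24 and lies beyond the scatter from both of the others.

Compound 4 (`Cc1cccc(N2CCN(Cc3cncn3Cc3ccc(C#N)cc3)C(=O)C2=O)c1C`) differs from compound 2 at a single place: 2,3-dimethylphenyl in place of 3-chlorophenyl on an amide-type nitrogen in a ring with 2,3-dimethylphenyl in place of 3-chlorophenyl on an amide-type nitrogen in a ring.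

Going by the values given here, no two of the measured compounds differ in one place only, so the data show no step at this position, and the expectation rests on the structural change alone. A small upward move is expected, and the estimated step of a number 0.26 log units higher from compound 2 to compound 4 (within the scatter) may not clear the scatter in this assay once it is measured. For compound 4 the estimated value is 1.5 with an expected range from 1.1 to 1.95 as the likely span.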

Compound 4, partition coefficient: 1.11
For compound 4 the middle estimate is 0.39 log units above the measured one; low and high end bracket the measured number.
By their numbers in this assay, from the lowest: compounds 4 and 2 (each within the scatter of the next); then compounds 1 and 3 (each within the scatter of the next).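

Moving from 3-chlorophenyl to 2,3-dimethylphenyl on the amide-type nitrogen in a ring gives the first step that can be read at this position: in this assay the step is a number 0.13 log units lower from compound 2 to compound 4 (within the scatter). Compound 2 and compound 4 therefore cannot be told apart in this assay, so this exchange of one aryl group for another leaves the reading unchanged within the scatter. No measurement shown here bears on why the two compounds read alike.

This single pair says nothing about a pyridyl ring, a carboxylic acid or an amine in place of the aryl group at this position. It also leaves open whether 2,3-dimethylphenyl would give a similar step on the core of compound 1 or of compound 3.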